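Amine exchange on the amide chain: notes on compound 4

The compounds below may be only part of what the source reports. "The series", "measured", "known", "first", "only" and "open" are said of these compounds alone.

Three compounds of the series have been run in a functional assay on MCF7 cells (Homo sapiens) for antiproliferative activity, read by MTT assay, with a stated time of 48 h; on this read-out higher numbers stand for weaker inhibition and lower numbers for stronger inhibition. Compound 1 `COc1ccc(-c2cc3ccc(OC)cc3nc2Nc2ccc(NC(=O)CN(C)C)cc2)cc1` gives 9600 nM. Compound 2 `CCN(CC)CC(=O)Nc1ccc(Nc2nc3cc(OC)ccc3cc2-c2ccc(OC)cc2)cc1` differs from compound 1 only by diethylamino in place of dimethylamino on a saturated chain carbon bound to a carbonyl carbon. Compound 2 gives 17300 nM; the change produced a 1.8-fold higher number from compound 1 to compound 2 (0.26 log units; within the scatter). Compound 3 `COc1ccc(-c2cc3cc(OC)ccc3nc2Nc2ccc(NC(=O)CN(C)C)cc2)cc1` gives 39500 nM, the highest of the three numbers, standing beyond the scatter from both compound 1 and compound 2. Compound 3 and compound 1 carry the same atoms joined differently; the difference between the two cores is not broken down here.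

Compound 4 `CCN(CC)CC(=O)Nc1ccc(Nc2nc3ccc(OC)cc3cc2-c2ccc(OC)cc2)cc1` has not yet been measured in this assay. It differs from compound 3 by diethylamino in place of dimethylamino on a saturated chain carbon bound to a carbonyl carbon, and the place of the change is the same word for word as in the step from compound 1 to compound 2, so the change is the same one, made on the core of compound 3 instead of the core of compound 1. Within the data shown here, the single measured instance of it, a 1.8-fold higher number from compound 1 to compound 2 (0.26 log units; within the scatter), stayed within the scatter. Nothing here shows how the change behaves on the core of compound 3. Resting on a 1.8-fold higher number from compound 1 to compound 2 (0.26 log units; within the scatter), the expected step is a 1.4-fold higher number from compound 3 to compound 4 (0.14 log units; within the scatter), a small rise at most. Compound 4 is therefore estimated at 55000 nM in this assay, with the likely range running from 20000 nM to 150000 nM. The estimate starts from the value of compound 3, 39500 nM, which already stands beyond the scatter from the other two numbers.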

Compound 4, half-maximal inhibitory concentration: > 50000 nM
Compound 4 ended at the assay's limit (the forecaster's own chance of this, stated with the estimate: 20%); the middle value does not contradict the limit.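

In this assay compound 4 gives > 50000 nM, which is a limit of the assay and not a number: the limit of > 50000 nM in this assay, at which 1 of the 4 values shown sits. The exchange of dimethylamino for diethylamino can therefore be read only as a floor, an at least 1.2-fold higher number from compound 3 to compound 4 (0.10 log units; that floor lies within the scatter), and that floor lies within the scatter. The two instances give no sign that the change behaves differently on the two cores, but they do not show that it has the same size on both, so no size can yet be carried from one core to the other: the same change on two cores in this assay, a 1.8-fold higher number (0.26 log units; within the scatter) from compound 1 to compound 2 and an at least 1.2-fold higher number (0.10 log units; that floor lies within the scatter) from compound 3 to compound 4; the limit leaves it open whether they differ.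

The compounds shown carry only dimethylamino and diethylamino on the amide chain, which leaves open how a ring amine such as pyrrolidine, piperidine or morpholine, or a longer chain between the carbonyl and the amine, would read in this assay. Also open, on these data alone, are where compound 4 lies beyond its limit and how the exchange behaves on any core other than these two.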